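Adding a third methoxy to a weak quinoxaline-type inhibitor

The compounds below may be only part of what the source reports. "The series", "measured", "known", "first", "only" and "open" are said of these compounds alone.

Measured so far:
compound 1 `Nc1cc(N)c2nc(-c3ccccc3)c(NCc3ccc(Cl)c(Cl)c3)nc2c1` gives 18600 nM in a functional assay on SF-539 cells (Homo sapiens) for inhibition, read by sulforhodamine B assay, with a stated time of 48 h; on this read-out higher numbers stand for weaker inhibition of growth and lower numbers for stronger inhibition of growth
compound 2 `COc1ccc(CNc2nc3cc(N)cc(N)c3nc2-c2ccccc2)cc1OC` gives 45700 nM in this assay

Within the data shown here, compound 2 stands at the higher of the two numbers, meaning the weaker growth inhibition; its only neighbour is compound 1, and the step of a 2.5-fold higher number from compound 1 to compound 2 (0.39 log units; beyond the scatter) separates them, a modest change that exceeds the usual scatter.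

Compound 3 `COc1cc(CNc2nc3cc(N)cc(N)c3nc2-c2ccccc2)cc(OC)c1OC` is compound 2 with one further change: methoxy in place of hydrogen on an aromatic carbon. Among the measured compounds shown here, no measured step involves such an addition, so the only related information is the step of a 2.5-fold higher number from compound 1 to compound 2 (0.39 log units; beyond the scatter), which swapped the whole substitution pattern of that ring rather than adding to it. That step was modest, and a single added methoxy is a smaller change still, so a step within or only slightly beyond the scatter is expected, if anything toward weaker inhibition.

Compound 3 is therefore estimated at 55000 nM in this assay, with a range from 20000 nM to 150000 nM, which would correspond to an expected step of a 1.2-fold higher number from compound 2 to compound 3 (0.08 log units; within the scatter).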

Compound 3, concentration for total growth inhibition: 7940 nM
Beside the measured number, compound 3's estimate is 6.9-fold (0.84 log units) above it, outside the stated range (below it).
By their numbers in this assay, from the lowest: compound 3; then compound 1; then compound 2.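

In this assay, adding methoxy at this ring position, ortho to a methoxy group and meta to a large group, gives a 5.8-fold lower number from compound 2 to compound 3 (0.76 log units; beyond the scatter) and so strengthens growth inhibition. The earlier step, a 2.5-fold higher number from compound 1 to compound 2 (0.39 log units; beyond the scatter), had tied the methoxy-bearing ring to weaker inhibition, but this result shows that the effect of methoxy on this ring depends on the pattern it completes, and that one small addition here can outweigh that earlier loss. Nothing available here explains why this addition strengthens inhibition.

From the compounds shown here alone, whether the gain is specific to methoxy remains open, and a hydroxyl, an ethoxy or a fluorine at the same position would help to test this. It is also unclear whether a similar addition would strengthen inhibition in the dichlorophenyl series of compound 1.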